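The source may report more compounds than this note shows. Statements on the series, on what has been measured and on what is new or still open speak of the compounds shown alone.

Working notes on the series. Compound 1 `CC1=CC[C@H](C(C)(C)NC(=S)N/N=C(\C)c2ccccc2)CC1` carries an unsubstituted aromatic ring on the hydrazone side; in a functional assay on NCI-H460 cells (Homo sapiens) for inhibition, read by sulforhodamine B assay, with a stated time of 48 h (a lower number here means a stronger inhibitor of growth, a higher number a weaker inhibitor of growth), compound 1 gives only a limit, > 100000 nM. Going by the values given here, compound 2 `COc1ccc(/C(C)=N/NC(=S)NC(C)(C)[C@H]2CC=C(C)CC2)cc1` is the methoxy analogue and the one member with an actual number: in this assay compound 2 gives 90600 nM. Among the compounds with values here, the step of an at least 1.1-fold lower number from compound 1 to compound 2 (0.04 log units; that floor lies within the scatter) is the sole measured change on this ring, and as it starts from the limit of > 100000 nM in this assay, at which 1 of the 2 values shown sits, it fixes little about substituent effects there.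

Compound 3 `CC1=CC[C@H](C(C)(C)NC(=S)N/N=C(\C)c2ccc([N+](=O)[O-])cc2)CC1` differs from compound 2 by nitro in place of methoxy on an aromatic carbon. Within the data shown here, no measured step involves a nitro group, so the only guide is that the one substituent change already seen stayed within the scatter. For compound 3 the step of a 1.1-fold lower number from compound 2 to compound 3 (0.03 log units; within the scatter) is therefore expected to lie within the scatter. Compound 3 is estimated at 85000 nM, with a range from 30000 nM to 200000 nM, and a real chance of a limit only.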

Compound 3, concentration for 50% growth inhibition: 50800 nM
Estimate against measurement, compound 3: 1.7-fold (0.22 log units) above; low and high end bracket the measured number.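

In this assay, going by these compounds alone, the step of a 1.8-fold lower number from compound 2 to compound 3 (0.25 log units; within the scatter) is the first at this position, on an aromatic carbon para to a large group, to join two actual numbers, and on this evidence nitro and methoxy there cannot be told apart. The step of an at least 1.9-fold lower number from compound 1 to compound 3 (0.29 log units; that floor lies within the scatter) starts from a limit and so gives only a floor, and that floor also stays within the scatter. Compound 3 adds a second actual number, yet the comparison with the unsubstituted ring remains open-ended: the limit of > 100000 nM in this assay, at which 1 of the 3 values shown sits.

From the compounds shown here alone, whether an amine or a carboxylic acid at this position gives a step beyond the scatter stays open. So does whether a change away from this aromatic ring, such as a longer chain in place of the methyl group on the hydrazone side, shifts the number in this assay at all.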